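Removing One Hydroxy From Compound 1

The compounds below may be only part of what the source reports. "The series", "measured", "known", "first", "only" and "open" are said of these compounds alone.

Measured in an ADME assay on MDCK cells (Canis lupus familiaris) for cytotoxicity; a lower number here means that less compound is tolerated, a higher number that more compound is tolerated:
- compound 1 `O=[N+]([O-])C1=CNc2nc(C(F)(F)F)nn2C1c1c(O)cc(O)cc1O`: 838000 nM
- compound 2 `O=[N+]([O-])C1=CNc2ncnn2C1c1c(O)cc(O)cc1O`: > 1030000 nM (a limit)
- compound 3 `O=[N+]([O-])C1=CNc2nc(-c3ccco3)nn2C1c1c(O)cc(O)cc1O`: 280000 nM

Compound 1 holds the higher of the two actual numbers, with a 3.0-fold lower number from compound 1 to compound 3 (0.48 log units; beyond the scatter). The value of compound 2 is a limit, not a number.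

Compound 4 `O=[N+]([O-])C1=CNc2nc(C(F)(F)F)nn2C1c1ccc(O)cc1O` follows from compound 1 by one change: hydrogen in place of hydroxy on an aromatic carbon.

For the measured compounds named here, no measured step touches a hydroxy group. The nearest guides exchange trifluoromethyl, hydrogen and furan-2-yl elsewhere, and they show an at least 1.2-fold higher number from compound 1 to compound 2 (0.08 log units; that floor lies within the scatter) and an at least 3.6-fold lower number from compound 2 to compound 3 (0.56 log units; beyond the scatter). Judging by these sizes, a modest drop in this assay is expected at most, and possibly none beyond the scatter. The expected change is a 1.5-fold lower number from compound 1 to compound 4 (0.18 log units; within the scatter). Compound 4 is estimated at 550000 nM, within an expected range from 220000 nM to 1000000 nM.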

Compound 4, half-maximal cytotoxic concentration: 258000 nM
Compound 4: middle estimate off by 2.1-fold (0.33 log units), on the high side; the measured number falls inside the stated range.
By their numbers in this assay, from the lowest: compounds 4 and 3 (each within the scatter of the next); then compound 1. At a limit, above all of these: compound 2.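

In this assay, hydrogen in place of the hydroxy ortho to a large group gives a 3.2-fold lower number from compound 1 to compound 4 (0.51 log units; beyond the scatter). For the compounds shown here, this shows that the number responds to a change on the six-membered aromatic ring, whereas the earlier steps only exchanged trifluoromethyl, hydrogen and furan-2-yl elsewhere in the molecule. Nothing given here accounts for the size of this step.

The compounds shown leave open whether a methoxy group or an amine at this position would behave like the hydroxy or like hydrogen. They also leave open whether losing this hydroxy has a similar effect when furan-2-yl or hydrogen replaces trifluoromethyl.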